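Fluoro on the phenyl of compound 2: working notes

The compounds below may be only part of what the source reports. "The series", "measured", "known", "first", "only" and "open" are said of these compounds alone.

Compound 1 (`COc1cc2ncnc(Nc3cc(O)[nH]n3)c2cc1OC`): < 100000 nM (a limit)
Compound 2 (`COc1cc2ncnc(Nc3cc(-c4ccccc4)[nH]n3)c2cc1OC`): 9300 nM

For the measured compounds named here, in a functional assay on PANC-1 cells (Homo sapiens) for cytotoxicity, read by MTT assay (on this read-out higher numbers stand for weaker inhibition and lower numbers for stronger inhibition), compound 2 gives 9300 nM, the only number so far. The entry for compound 1 is a limit, < 100000 nM, and not a number.

The next compound, compound 3 (`COc1cc2ncnc(Nc3cc(-c4ccc(F)cc4)[nH]n3)c2cc1OC`), takes the phenyl of compound 2 to 4-fluorophenyl, with fluoro in place of hydrogen on an aromatic carbon, para to a large group (fluoro in place of hydrogen on an aromatic carbon).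

One measured step is available, a step that the limit leaves unreadable from compound 1 to compound 2. It swaps a different group at a different place and rests on (the limit of < 100000 nM in this assay, at which 1 of the 2 values shown sits), so it offers no size to carry over. Going by the values given here, no measured step covers the fluoro change itself, so the only anchor is compound 2 at 9300 nM. No step beyond the usual scatter is expected in this assay, and no direction can be called.

The expected step is a 1.1-fold lower number from compound 2 to compound 3 (0.04 log units; within the scatter). For compound 3 the estimate is 8500 nM, with an expected range from 3000 nM to 22000 nM.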

Compound 3, half-maximal inhibitory concentration: 69400 nM
Compound 3: middle estimate off by 8.2-fold (0.91 log units), on the low side; measured number above the stated range.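

In this assay, for the compounds shown here, the change from phenyl to 4-fluorophenyl gives a 7.5-fold higher number from compound 2 to compound 3 (0.87 log units; beyond the scatter) and is the first readable step, showing that a single fluoro in place of hydrogen on this aromatic carbon, para to a large group, weakens inhibition rather than leaving it unchanged. The steps from compound 1 cannot be read, as its entry is a limit and not a number: the limit of < 100000 nM in this assay, at which 1 of the 3 values shown sits. Nothing given here accounts for the weaker inhibition of compound 3.

The series holds only hydrogen and fluoro at this place on the phenyl, so a single step cannot tell whether the loss is particular to fluoro or would also follow from other replacements for hydrogen, such as chloro, methyl, methoxy, an amine or a carboxylic acid. Also open, going by these compounds, is whether fluoro elsewhere on the phenyl would carry the same cost, and whether the same step would appear in any assay other than this assay.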